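This account rests on a few compounds, and the source may have more. Where it says the series, first, only, none or still open, it means among the compounds named here.

Measured compounds:
- compound 1, `O=C(O)CN1C(=O)/C(=C/c2nc3ccccc3n2Cc2ccccc2)SC1=S`: 10800 nM
- compound 2, `Cc1ccc(Cn2c(/C=C3\SC(=S)N(CC(=O)O)C3=O)nc3ccccc32)cc1`: 2640 nM

Among the compounds with values here, of the two numbers seen in a functional assay on PC-3 cells (Homo sapiens) for cytotoxicity, read by MTT assay, with a stated time of 48 h (on this read-out higher numbers stand for weaker inhibition and lower numbers for stronger inhibition), compound 2 has the lower one, and its only neighbour is compound 1, separated by the step of a 4.1-fold lower number from compound 1 to compound 2 (0.61 log units; beyond the scatter), a change from hydrogen to methyl on an aromatic carbon. So compound 2 stands as the stronger of the two measured compounds on this assay.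

Compound 3, `CCn1c(/C=C2\SC(=S)N(CC(=O)O)C2=O)nc2ccccc21`, has not yet been tested in this assay. Its difference from compound 2 is methyl in place of 4-methylphenyl on a saturated chain carbon bound to an aromatic nitrogen. Within the data shown here, no measured step covers the loss of the whole 4-methylphenyl group; the only step known, a 4.1-fold lower number from compound 1 to compound 2 (0.61 log units; beyond the scatter), shows that a methyl added to that ring made a modest difference, which suggests the ring itself is not a silent part of compound 2. Removing it is therefore expected to weaken inhibition, probably to a number near or above that of compound 1. For compound 3, the value in this assay is estimated at 12000 nM, within a range from 3000 nM to 50000 nM. This estimate corresponds to an expected step of a 4.5-fold higher number from compound 2 to compound 3 (0.66 log units; beyond the scatter).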

Compound 3, half-maximal inhibitory concentration: 3250 nM
The estimate for compound 3 lay 3.7-fold (0.57 log units) above the measured number, within the range that was stated.
By their numbers in this assay, from the lowest: compounds 2 and 3 (each within the scatter of the next); then compound 1.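

In this assay, replacing the 4-methylbenzyl of compound 2 with ethyl gives a 1.2-fold higher number from compound 2 to compound 3 (0.09 log units; within the scatter), so the two compounds cannot be told apart, even though the change removes a whole six-membered aromatic ring from the saturated chain carbon bound to the aromatic nitrogen. The same exchange made on the plain benzyl compound gives a 3.3-fold lower number from compound 1 to compound 3 (0.52 log units; beyond the scatter), which shows that an aromatic ring at this position is not required for the lower numbers seen here, and that carrying a ring does not by itself set the number: compound 1 and compound 2 both have one, yet only compound 2 matches the ringless compound 3. No measurement of any other kind is available to explain these results.

The compounds shown leave open what a longer chain such as butyl, or a chain ending in an amine, would do at this position. They also leave open whether a small group is needed there at all, since a plain hydrogen on that aromatic nitrogen is not among them.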